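The source may report more compounds than this note shows. Statements on the series, on what has been measured and on what is new or still open speak of the compounds shown alone.

Measured compounds:
compound 1, `CNC(=O)CCc1ccncc1-c1ccc2ccccc2c1`, 8980 nM;
compound 2, `CNC(=O)/C=C/c1ccncc1-c1ccc2ccccc2c1`, 8680 nM;
compound 3, `O=C(/C=C/c1ccncc1-c1ccc2cc[nH]c2c1)N1CCOCC1`, > 10000 nM.

The series is read in a functional assay on MDA-MB-231 cells (Homo sapiens) for inhibition, read by sulforhodamine B assay, with a stated time of 72 h; on this read-out lower numbers stand for stronger inhibition of growth and higher numbers for weaker inhibition of growth. Compound 3 returned only a limit of the assay, (the limit of > 10000 nM in this assay, at which 1 of the 3 values shown sits). Compound 2 carries the lowest of the two numbers given, yet the change a 1.0-fold lower number from compound 1 to compound 2 (0.01 log units; within the scatter) is within the scatter, so compound 1 and compound 2 stand level. Compound 4, `O=C(/C=C/c1ccncc1-c1ccc2ccccc2c1)N1CCOCC1`, differs from compound 2 by morpholin-4-yl in place of methylamino on a carbonyl carbon. For the measured compounds named here, no measured step matches this change; the nearest evidence is compound 3, which also bears a (morpholin-4-yl)carbonyl group and reached only the limit. Compound 4 is therefore expected at 12000 nM, between 5000 nM and 25000 nM, an expected step of a 1.4-fold higher number from compound 2 to compound 4 (0.14 log units; within the scatter) toward weaker growth inhibition, with a real chance the assay reports only a limit.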

Compound 4, concentration for 50% growth inhibition: 8980 nM
Estimate against measurement, compound 4: 1.3-fold (0.13 log units) above; the range from low to high includes it.
By their numbers in this assay, from the lowest: compounds 2, 1 and 4 (each within the scatter of the next). At a limit, above all of these: compound 3.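

In this assay, morpholin-4-yl in place of methylamino on a carbonyl carbon gives a 1.0-fold higher number from compound 2 to compound 4 (0.01 log units; within the scatter), so compound 2 and compound 4 stand level. The earlier compounds had shown only a change in the chain, whereas this result shows that the group on the carbonyl carbon can gain a six-membered ring and give up a hydrogen-bond donor without a readable shift. Compound 3, which also bears (morpholin-4-yl)carbonyl, stands at a limit, so its step from compound 4 cannot be read: the limit of > 10000 nM in this assay, at which 1 of the 4 values shown sits.

Going by these compounds, whether a carboxylic acid or a basic amine such as piperazine on this carbonyl carbon would move the number beyond the scatter remains open.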